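The source may report more compounds than this note shows. Statements on the series, on what has been measured and on what is new or still open speak of the compounds shown alone.

Compound 2 `Cc1ccc(-c2cc(Br)ccc2OCc2ccc(F)cc2F)n1-c1cc(C(=O)O)cc(N2CCCCC2=O)c1` gives the lower of the two values: in an assay on CHO cells for displacement of a labelled ligand from prostaglandin E2 receptor EP1 subtype (Homo sapiens) (a lower number here means a stronger inhibitor, a higher number a weaker inhibitor), compound 2 gives 1.26 nM, while compound 1 `Cc1ccc(-c2cc(Cl)ccc2OCc2ccc(F)cc2F)n1-c1cc(C(=O)O)ccc1F` gives 6.31 nM, a gap that lies beyond the usual scatter. Compound 3 `CC(=O)Nc1cc(C(=O)O)cc(-n2c(C)ccc2-c2cc(Br)ccc2OCc2ccc(F)cc2F)c1` has not yet been measured and differs from compound 2 in one place: acetamido in place of 2-oxopiperidin-1-yl on an aromatic carbon. Both groups carry an amide carbonyl, so only a small step is expected here, if any beyond the scatter, and most likely toward a somewhat higher number. On that basis compound 3 is estimated at 2.5 nM in this assay, within a range of 0.8 nM to 8 nM, corresponding to an expected step of a 2.0-fold higher number from compound 2 to compound 3 (0.30 log units; within the scatter).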

Compound 3, half-maximal inhibitory concentration: 0.398 nM
Beside the measured number, compound 3's estimate is 6.3-fold (0.80 log units) above it; measured number below the stated range.
By their numbers in this assay, from the lowest: compound 3; then compound 2; then compound 1.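

On this aromatic carbon, meta to a carboxy group, the six-membered non-aromatic ring of 2-oxopiperidin-1-yl is not needed for a low number: in this assay, the open-chain acetamido group gives a 3.2-fold lower number from compound 2 to compound 3 (0.50 log units; beyond the scatter) and brings one hydrogen-bond donor with fewer heavy atoms. No measurement shown accounts for this step. Going by these compounds, it remains open whether the amide hydrogen or the smaller group goes with the lower number. An N-methylacetamido group or a plain amine at this place would help separate the two.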